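Bromo to Iodo at the Para Position of the Aryl Ring

A few compounds are considered here, and "the series" means these few. Any claim that something is new, unique, unknown or untested is made for them only; others in the source may bear on it.

Of the compounds shown here, two with a shared core have been measured in a functional assay on the whole organism for inhibition, with Lemna aequinoctialis as the target, tested at 100 ug/mL; on this read-out lower numbers stand for less inhibition of growth and higher numbers for more inhibition of growth at the one concentration tested. Compound 1 `Cc1ccc(NC(=S)N/N=C2\C(=O)Nc3ccc([N+](=O)[O-])cc32)cc1` gives 20% in this assay. Compound 2 `O=C1Nc2ccc([N+](=O)[O-])cc2/C1=N/NC(=S)Nc1ccc(Br)cc1` gives 15% in this assay. Among the measured compounds shown here, the single step between them, bromo in place of methyl on an aromatic carbon, reads a number 5 percentage points lower from compound 1 to compound 2 (within the scatter), so the two numbers sit within the scatter of each other and compound 2 cannot be set apart from compound 1 on this read-out.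

Compound 3 `O=C1Nc2ccc([N+](=O)[O-])cc2/C1=N/NC(=S)Nc1ccc(I)cc1` is not yet measured. Its change from compound 2 is iodo in place of bromo on an aromatic carbon. For the measured compounds named here, only the step from compound 1 to compound 2 bears on this change, since it too exchanges one group at the same place on the aryl ring, and that step stayed within the scatter. With nothing beyond the scatter to build on, compound 3 is expected to differ from compound 2 by no change at the digits printed from compound 2 to compound 3 (within the scatter), which is no step beyond the scatter. In this assay compound 3 is therefore estimated at 15%, with a range from 5% to 28%.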

Compound 3, percent growth inhibition at one concentration: 10%
Compound 3: middle estimate off by 5 percentage points, on the high side; the range from low to high includes it.
By their numbers in this assay, from the lowest: compounds 3, 2 and 1 (each within the scatter of the next).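

In this assay iodo in place of bromo on this aromatic carbon, para to a large group, reads a number 5 percentage points lower from compound 2 to compound 3 (within the scatter) and stays a step that cannot separate the two compounds. The wider comparison, iodo in place of methyl at the same place, reads a number 10 percentage points lower from compound 1 to compound 3 (within the scatter) and so also stays inside the scatter, which the earlier pair alone could not show. Methyl, bromo and iodo at this place therefore cannot be told apart on this read-out, and no order among them can be drawn, while nothing measured alongside these numbers accounts for them.

What the compounds shown leave open is whether any group at this place can carry the growth inhibition beyond the scatter, for instance an amine, a carboxylic acid or a longer chain such as butyl in place of the halogen. Also open, from the compounds shown here alone, is whether methyl, bromo and iodo would stay indistinguishable at other concentrations, since each compound here has a reading at only one.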